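This account rests on a few compounds, and the source may have more. Where it says the series, first, only, none or still open, it means among the compounds named here.

Measured so far:
- compound 1 `O=C(Nc1cccc(-n2cc(-c3ccncc3)c(-c3cc(O)cc(Cl)c3)n2)c1)Nc1ccc(Cl)c(C(F)(F)F)c1` gives 84% in a functional assay on UO-31 cells (Homo sapiens) for inhibition, read by sulforhodamine B assay, with a stated time of 48 h, tested at 1 uM; a higher number here means a weaker effect of the compound at the concentration tested, a lower number a stronger effect
- compound 2 `O=C(Nc1cccc(-n2cc(-c3ccncc3)c(-c3cc(O)cc(Cl)c3)n2)c1)Nc1ccc(Cl)c(Cl)c1` gives 78% in this assay
- compound 3 `COc1cc(Cl)cc(-c2nn(-c3cccc(NC(=O)Nc4ccc(Cl)c(C(F)(F)F)c4)c3)cc2-c2ccncc2)c1` gives 64% in this assay

Compound 3 stands lowest of the three numbers in this assay; the nearest is compound 2, the furthest compound 1, and both gaps lie beyond the scatter. Going by the values given here, the step from compound 1 to compound 3 is a number 20 percentage points lower from compound 1 to compound 3 (beyond the scatter), the only change beyond the scatter in the set.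

Compound 4 `COc1cc(Cl)cc(-c2nn(-c3cccc(NC(=O)Nc4ccc(Cl)c(Cl)c4)c3)cc2-c2ccncc2)c1` differs from compound 3 in one place: chloro in place of trifluoromethyl on an aromatic carbon. The same exchange has been measured once, from compound 1 to compound 2, where it gave a number 6 percentage points lower from compound 1 to compound 2 (within the scatter), a move that stays within the scatter. Among the compounds with values here, no other measured step bears on it. The expectation for compound 4 in this assay is therefore no step beyond the scatter from compound 3, with at most a small drift downward: a number 4 percentage points lower from compound 3 to compound 4 (within the scatter).

The estimate for compound 4 in this assay is 60%, with a range of 45% to 75%.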

Compound 4, a percentage reported as activity, at one concentration (the size of the read-out at that concentration, not a potency): 88%
The estimate for compound 4 lay 28 percentage points below the measured number; measured number outside the range, above it.
By their numbers in this assay, from the lowest: compound 3; then compounds 2, 1 and 4 (each within the scatter of the next).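

With methyl on the oxygen, chloro in place of trifluoromethyl gives a number 24 percentage points higher from compound 3 to compound 4 (beyond the scatter) in this assay, so the exchange at this position is not neutral on every core. Its outcome depends on the group on the oxygen: the same change on two cores in this assay, a number 6 percentage points lower (within the scatter) from compound 1 to compound 2 and a number 24 percentage points higher (beyond the scatter) from compound 3 to compound 4, 30 percentage points apart, beyond the scatter of two such steps

Read the other way, methyl in place of hydrogen on the oxygen gives a number 10 percentage points higher from compound 2 to compound 4 (within the scatter), so the stronger effect seen with the 4-chloro-3-(trifluoromethyl)phenyl group does not carry over to the 3,4-dichlorophenyl group: the same change on two cores in this assay, a number 20 percentage points lower (beyond the scatter) from compound 1 to compound 3 and a number 10 percentage points higher (within the scatter) from compound 2 to compound 4, 30 percentage points apart, beyond the scatter of two such steps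

Going by these compounds, this coupling rests on a single set of four compounds, and what underlies it stays open. Also open, on these data alone, is whether it holds with bromo or a nitrile at this position, or with an ethyl on the oxygen.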